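Carboxy Replaces Methylsulfanyl: Cytotoxicity Expected Unchanged

This account rests on a few compounds, and the source may have more. Where it says the series, first, only, none or still open, it means among the compounds named here.

Of the compounds shown here, three have been tested in an ADME assay on BJ cells (Homo sapiens) for cytotoxicity, with a stated time of 72 h; on this read-out lower numbers stand for an effect already at smaller amounts and higher numbers for an effect only at larger amounts of compound. Compound 1 `Cc1cc(NC(=O)Nc2ccc(Cl)c(Cl)c2)c2ccccc2n1` gives 23000 nM in this assay. Compound 2 `CSc1ccc(NC(=O)Nc2cc(C)nc3ccccc23)cc1` reaches only a limit of this assay, > 25000 nM. Compound 3 `Cc1cc(NC(=O)Nc2ccc([N+](=O)[O-])c(C(F)(F)F)c2)c2ccccc2n1` likewise stops at a limit, > 25000 nM. Compound 2 thus stands at the limit of > 25000 nM in this assay, at which 2 of the 3 values shown sit; its value is a boundary rather than a number, and one other compound shown shares that boundary.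

Compound 4 `Cc1cc(NC(=O)Nc2ccc(C(=O)O)cc2)c2ccccc2n1` has not yet been measured. It differs from compound 2 in one place: carboxy in place of methylsulfanyl on an aromatic carbon. Going by the values given here, no pair of measured compounds differing in a single place is available; there is no measured step to draw on. All three values shown lie at large amounts of compound, and none of them points to an effect at smaller amounts. The expected step that the limit leaves unreadable from compound 2 to compound 4 is therefore small, none beyond the usual scatter. Compound 4 is estimated at 30000 nM in this assay, within a range from 15000 nM to 60000 nM, and it is quite likely that only a limit will again be reported.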

Compound 4, half-maximal effective concentration: > 25000 nM
Compound 4 ended at the assay's limit; the forecaster's own chance of this, stated with the estimate: 70%; the middle value is on the limit's open side.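

Going by these compounds alone, compound 2 and compound 4 each stop at a limit in this assay, not at a number, so no step between them can be read. The compounds shown leave open whether carboxy in place of methylsulfanyl on an aromatic carbon changes the cytotoxicity at all.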